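The compounds below may be only part of what the source reports. "The series", "measured", "known", "first", "only" and "open" are said of these compounds alone.

In a functional assay on the whole organism with Mus musculus as the target (on this read-out higher numbers stand for an effect only at larger amounts of compound and lower numbers for an effect already at smaller amounts), compound 1 `CCNC(=O)/C=C1\CCc2ccc(F)cc21` gives 70 mg/kg. Compound 2 `CCCNC(=O)/C=C1\CCc2ccc(F)cc21` gives > 100 mg/kg, and this is a limit of the assay, not a number. The position of compound 2 is therefore known only as the limit of > 100 mg/kg in this assay, at which 1 of the 2 values shown sits.

Compound 3 `O=C(/C=C1\CCc2ccc(F)cc21)NC1CC1` keeps the shared core and differs from compound 2 by cyclopropyl in place of propyl on an amide-type nitrogen. In words, this is cyclopropyl in place of propyl on an amide-type nitrogen.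

Among the compounds with values here, only one measured step bears on this change: an at least 1.4-fold higher number from compound 1 to compound 2 (0.15 log units; that floor lies within the scatter). That step alters the same group on the nitrogen, but it adds no ring, so it is an imperfect guide. Its true size is also unknown, since one end of it is a limit, and its floor lies within the scatter. On the evidence of an at least 1.4-fold higher number from compound 1 to compound 2 (0.15 log units; that floor lies within the scatter), no clear step in either direction beyond the scatter is expected in this assay, and compound 3 may also end up reported only as a limit.

The expected change is an at least 1.1-fold lower number from compound 2 to compound 3 (0.04 log units; that floor lies within the scatter).

For compound 3, the estimated dose is 90 mg/kg, with an expected range from 40 mg/kg to 200 mg/kg.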

Compound 3, dose for half-maximal effect: 66 mg/kg
Compound 3: the middle estimate sits 1.4-fold (0.13 log units) above what was measured, within the range that was stated.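

Putting cyclopropyl in place of ethyl on the amide-type nitrogen gives a 1.1-fold lower number from compound 1 to compound 3 (0.03 log units; within the scatter), so the two compounds cannot be told apart in this assay. This shows that a group with a three-membered ring can sit on this nitrogen and still give a measured dose, whereas the propyl group of compound 2, with the same count of heavy atoms, gives only a limit of the assay. Cyclopropyl in place of propyl gives an at least 1.5-fold lower number from compound 2 to compound 3 (0.18 log units; that floor lies within the scatter), and this is a floor rather than a true size because one end of the step is a limit: the limit of > 100 mg/kg in this assay, at which 1 of the 3 values shown sits.

On these data alone, the true size of the gap between the propyl and cyclopropyl groups therefore stays open, and with it the question of whether closing the chain into a ring changes the dose beyond the scatter. Also open, as far as these compounds go, is what a larger ring such as cyclopentyl, a branched chain such as isopropyl, or a chain ending in an amine would do on this nitrogen.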